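The source may hold more compounds than are shown below. What is called first, only, known or untested is meant among the compounds shown, and "the series" means these compounds.

Compound 1, `CC(O)(COc1ccccc1C(F)(F)F)C(=O)Nc1ccc(S(F)(F)(F)(F)F)cc1`, is the reference point of this small set. In a functional assay on DU-145 cells (Homo sapiens) for antiproliferative activity, read by propidium iodide staining, with a stated time of 96 h (a higher number here means a weaker inhibitor, a lower number a stronger inhibitor), compound 1 gives 7100 nM. Compound 2, `CC(O)(COc1ccccc1OC(F)(F)F)C(=O)Nc1ccc(S(F)(F)(F)(F)F)cc1`, is its partner, and in this assay compound 2 gives 16800 nM. Among the measured compounds shown here, the single change between them, (trifluoromethoxy in place of trifluoromethyl on an aromatic carbon), produced a 2.4-fold higher number from compound 1 to compound 2 (0.37 log units; beyond the scatter). Compound 3, `CC(O)(COc1ccccc1C(F)(F)F)C(=O)Nc1cccc(S(F)(F)(F)(F)F)c1`, shares its atoms with compound 1 but joins them differently; the difference between the two cores is not broken down here. In this assay compound 3 gives 52200 nM, the highest of the three numbers, with compound 2 standing nearest to it and compound 1 furthest from it. Compound 4, `CC(O)(COc1ccccc1OC(F)(F)F)C(=O)Nc1cccc(S(F)(F)(F)(F)F)c1`, is not yet measured. It stands to compound 3 as compound 2 stands to compound 1, by the same change, (trifluoromethoxy in place of trifluoromethyl on an aromatic carbon). For the measured compounds named here, the step from compound 3 to compound 4 in this assay is expected to be about the same size as the earlier one, a 2.3-fold higher number from compound 3 to compound 4 (0.36 log units; beyond the scatter), because a 2.4-fold higher number from compound 1 to compound 2 (0.37 log units; beyond the scatter) is the only direct guide the set offers for this change. On that basis compound 4 is estimated at 120000 nM, with a likely range from 50000 nM to 300000 nM.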

Compound 4, half-maximal inhibitory concentration: 38100 nM
Compound 4: the middle estimate sits 3.1-fold (0.50 log units) above what was measured; the whole stated range lies above it.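

On the core of compound 3, trifluoromethoxy in place of trifluoromethyl gives a 1.4-fold lower number from compound 3 to compound 4 (0.14 log units; within the scatter) in this assay, so the clear step seen on the core of compound 1 does not reappear there. The change therefore does not carry over with a fixed size from one core to the other, and the two steps differ: the same change on two cores in this assay, a 2.4-fold higher number (0.37 log units; beyond the scatter) from compound 1 to compound 2 and a 1.4-fold lower number (0.14 log units; within the scatter) from compound 3 to compound 4, 3.2-fold (0.51 log units) apart, beyond the scatter of two such steps. This shows that, for these two pairs, the size of the step depends on the core it is made on; it does not show which feature of the cores is responsible, and two pairs give no rule for how the change would behave on any further core in the series.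

As far as these compounds go, it remains open whether another group in the same place, such as a nitrile, a chlorine or a methoxy, would follow the step seen on the core of compound 1 or the one on the core of compound 3. From the compounds shown here alone, all four compounds also keep the hydroxyl and the amide, so the result of replacing that hydroxyl with an amine on either core also stays open.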